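Compound 4: a bromophenyl swap on the amide

The compounds below may be only part of what the source reports. "The series", "measured", "known", "first", "only" and "open" are said of these compounds alone.

In a functional assay on K562 cells (Homo sapiens) for inhibition, read by MTT assay, with a stated time of 48 h (on this read-out lower numbers stand for stronger inhibition and higher numbers for weaker inhibition), compound 3 `Nc1n[nH]c2cc(-c3cn([C@@H]4CN[C@H](C(=O)Nc5ccc(Cl)c(C(F)(F)F)c5)C4)nn3)ccc12` gives 8320 nM. Compound 1 `CC(=O)Nc1ccc(-c2cn([C@@H]3CN[C@H](C(=O)Nc4ccc(Cl)c(C(F)(F)F)c4)C3)nn2)cn1` gives 8980 nM, within the scatter of compound 3, while compound 2 `CC(C)(C)OC(=O)N1C[C@@H](n2cc(-c3ccc4c(N)n[nH]c4c3)nn2)C[C@H]1C(=O)Nc1ccc(Br)cc1` gives 3710 nM, a lower number with a gap beyond the scatter.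

Compound 4 `Nc1n[nH]c2cc(-c3cn([C@@H]4CN[C@H](C(=O)Nc5ccc(Br)cc5)C4)nn3)ccc12` is built from compound 3 by one exchange: 4-bromophenyl in place of 4-chloro-3-(trifluoromethyl)phenyl on an amide-type nitrogen. For the measured compounds named here, no measured step tests this exchange. Going by the values given here, the only single-place step available, a 1.1-fold lower number from compound 1 to compound 3 (0.03 log units; within the scatter), concerns a different group and stays within the scatter, so it says little about the new change. Compound 2 does carry the 4-bromophenyl group and gives 3710 nM, but it differs from compound 4 in another place as well. It therefore offers only a weak hint towards a lower number.

With so little evidence, no step beyond the scatter is expected in this assay, only a slight drift downward. The expected change, a 1.4-fold lower number from compound 3 to compound 4 (0.14 log units; within the scatter), is correspondingly small. For compound 4 the estimate is 6000 nM, with an expected range from 2500 nM to 14000 nM.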

Compound 4, half-maximal inhibitory concentration: 10300 nM
The estimate for compound 4 lay 1.7-fold (0.23 log units) below the measured number, and the stated range covers the measured number.
By their numbers in this assay, from the lowest: compound 2; then compounds 3, 1 and 4 (each within the scatter of the next).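

In this assay, a 1.2-fold higher number from compound 3 to compound 4 (0.09 log units; within the scatter) shows that 4-bromophenyl and 4-chloro-3-(trifluoromethyl)phenyl on the amide-type nitrogen cannot be told apart on this read-out, even though the entering group has fewer heavy atoms than the leaving group. Compound 4 also gives a clean test of the other place: with 4-bromophenyl held constant, a 2.8-fold higher number from compound 2 to compound 4 (0.44 log units; beyond the scatter) comes with hydrogen in place of tert-butoxycarbonyl on the amine nitrogen in the ring, and this step lies beyond the scatter. The lower number of compound 2 therefore goes with the tert-butoxycarbonyl group and not with the 4-bromophenyl group, although no measurement here accounts for either step.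

The compounds shown leave open whether an unsubstituted phenyl, or a phenyl carrying an amine or a carboxylic acid, on the amide-type nitrogen would also stay within the scatter. From the compounds shown here alone, it also remains open whether the tert-butoxycarbonyl step would hold alongside 4-chloro-3-(trifluoromethyl)phenyl, and whether an acetyl group or a longer alkyl chain on the ring nitrogen would move the number in the same direction.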